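Aryl swap on the ring amine: compound 3 to compound 4

The source may hold more compounds than are shown below. What is called first, only, known or untested is meant among the compounds shown, and "the series" means these compounds.

Measured so far in a functional assay on MCF7 cells (Homo sapiens) for cytotoxicity, read by MTT assay, with a stated time of 24 h; on this read-out lower numbers stand for stronger inhibition and higher numbers for weaker inhibition:
- compound 1 `COc1cccc(N2CCN(CC(=O)N3CCN(c4nnc(-c5ccc(C)cc5)c(-c5ccc(C)cc5)n4)CC3)CC2)c1` gives 867000 nM
- compound 2 `COc1ccc(-c2nnc(N3CCN(C(=O)CN4CCN(c5ccc([N+](=O)[O-])cc5)CC4)CC3)nc2-c2ccc(OC)cc2)cc1` gives > 801000 nM, which is a limit of this assay and not a number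
- compound 3 `COc1ccccc1N1CCN(CC(=O)N2CCN(c3nnc(-c4ccc(Cl)cc4)c(-c4ccc(Cl)cc4)n3)CC2)CC1` gives 330000 nM

Compound 3 holds the lowest of the two numbers in hand; the nearest, that of compound 1, sits beyond the scatter above it. Compound 4 `O=C(CN1CCN(c2cccc(Cl)c2)CC1)N1CCN(c2nnc(-c3ccc(Cl)cc3)c(-c3ccc(Cl)cc3)n2)CC1` differs from compound 3 by 3-chlorophenyl in place of 2-methoxyphenyl on an amine nitrogen in a ring. Among the compounds with values here, no pair of measured compounds differing in one place is available, so no measured step guides this change. The step from compound 3 to compound 4 is expected to stay within the scatter, with no clear direction. Compound 4 is accordingly expected to give about 320000 nM in this assay, within 110000 nM to 950000 nM. That estimate corresponds to an expected step of a 1.0-fold lower number from compound 3 to compound 4 (0.01 log units; within the scatter).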

Compound 4, half-maximal inhibitory concentration: > 803000 nM
Compound 4 gave a limit, no number; the forecaster's own chance of this, stated with the estimate: 20%; middle value at least 2.5-fold (0.39 log units) from the limit.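

Working from this assay, the swap on the amine nitrogen in the ring gives the first one-place step in the series: an at least 2.4-fold higher number from compound 3 to compound 4 (0.38 log units; beyond the scatter). Compound 4 gives > 803000 nM, which is a limit of this assay and not a number. The aryl group at this position therefore matters, and 3-chlorophenyl does not match 2-methoxyphenyl on the core of compound 3.

From the compounds shown here alone, it remains open whether the step follows from the methoxy group leaving, the chlorine entering or the substituent's place on the phenyl ring. An unsubstituted phenyl or a benzyl group at this nitrogen would help to separate these readings.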